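Cytotoxicity limits and a 4-propylphenyl change

This account rests on a few compounds, and the source may have more. Where it says the series, first, only, none or still open, it means among the compounds named here.

Compound 1 `CCCCCC(=O)Nc1cc2nc(C3CCCCC3)[nH]c2cc1N1CCCC1`: > 100 ug/mL (a limit)
Compound 2 `CCOCCOC(=O)Nc1cc2nc(C3CCCCC3)[nH]c2cc1N(C)C`: > 100 ug/mL (a limit)

In an ADME assay on Vero cells (Chlorocebus sabaeus) for cytotoxicity, read by resazurin assay, with a stated time of 3 days (on this read-out lower numbers stand for stronger inhibition and higher numbers for weaker inhibition), compound 2 stands at > 100 ug/mL, which is a limit of the assay and not a number. Compound 1 stands at the same limit, > 100 ug/mL. Compound 3 `CCCc1ccc(C(=O)Nc2cc3nc(C4CCCCC4)[nH]c3cc2N(C)C)cc1` differs from compound 2 on a carbonyl carbon, with 4-propylphenyl in place of 2-ethoxyethoxy on a carbonyl carbon. Within the data shown here, no measured step shows what such a change does in this assay. A modest move towards stronger inhibition is expected, and it may not pass the usual scatter. Because the limit of > 100 ug/mL in this assay, at which 2 of the 2 values shown sit, another result at the limit remains quite possible. The expected change is an at least 1.1-fold lower number from compound 2 to compound 3 (0.04 log units; that floor lies within the scatter). Compound 3 is estimated at 90 ug/mL, with an expected range of 30 ug/mL to 200 ug/mL.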

Compound 3, half-maximal inhibitory concentration: > 100 ug/mL
Compound 3: only a limit was reported; the forecaster's own chance of this, stated with the estimate: 55%; middle value at least 1.1-fold (0.04 log units) from the limit.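

In this assay compound 3 gives > 100 ug/mL, a limit and not a number. Compound 2 also sits at a limit, so no step can be read between compound 2 and compound 3. The compounds shown leave open what any of these changes does to a measurable value in this assay, as all results sit at one limit: the limit of > 100 ug/mL in this assay, at which 3 of the 3 values shown sit.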